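Trifluoromethyl on the acid ring of a biaryl acid

This account rests on a few compounds, and the source may have more. Where it says the series, first, only, none or still open, it means among the compounds named here.

Measured compounds:
compound 1, `CC(C)N(C(=O)COc1ccc(-c2ccc(C(=O)O)cc2)cc1)C(C)C`: 830 nM
compound 2, `CC(C)N(C(=O)COc1ccc(-c2c(F)cc(C(=O)O)cc2F)cc1)C(C)C`: > 10000 nM
compound 3, `Cc1cc(C(=O)O)cc(C)c1-c1ccc(OCC(=O)N(C(C)C)C(C)C)cc1`: > 10000 nM

Compound 1 is the only one of the three to give a number in an assay on Prostate gland for inhibition of 3-oxo-5-alpha-steroid 4-dehydrogenase 2 (Homo sapiens); a lower number here means a stronger inhibitor, a higher number a weaker inhibitor; in that assay compound 1 gives 830 nM. Compound 2 gives only a limit, > 10000 nM. Compound 3 likewise gives only a limit, > 10000 nM. Both of these, which add substituents to the ring that carries the carboxy group of the shared core, sit at the limit of > 10000 nM in this assay, at which 2 of the 3 values shown sit.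

The step that follows leads from compound 1 to compound 4, `CC(C)N(C(=O)COc1ccc(-c2ccc(C(=O)O)cc2C(F)(F)F)cc1)C(C)C`. The change is trifluoromethyl in place of hydrogen on an aromatic carbon, ortho to a large group and meta to the carboxy group. Again the ring that carries the carboxy group is the one substituted. Compounds 2 and 3 show that substitution on this ring has so far removed measurable inhibition in this assay. A weakening step, beyond the usual scatter, is therefore expected here as well, though with a single group rather than two it may be less severe. For compound 4 an inhibitory concentration of 5000 nM is expected, within 1500 nM to 20000 nM, which is an expected step of a 6.0-fold higher number from compound 1 to compound 4 (0.78 log units; beyond the scatter).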

Compound 4, half-maximal inhibitory concentration: 570 nM
Estimate against measurement, compound 4: 8.8-fold (0.94 log units) above; measured number below the stated range.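

In this assay, trifluoromethyl in place of hydrogen, ortho to a large group and meta to the carboxy group, gives a 1.5-fold lower number from compound 1 to compound 4 (0.16 log units; within the scatter), so this change has no effect that can be told from the scatter. Within the data shown here, the earlier compounds showed only that two added groups on the ring that carries the carboxy group coincide with limits rather than numbers, and steps to those limits cannot be read. Compound 4 shows that a single large group on this ring is compatible with a measured value, so substitution on this ring does not in itself bring a compound to the limit where compound 2 and compound 3 sit: the limit of > 10000 nM in this assay, at which 2 of the 4 values shown sit.

The compounds shown leave open whether the number of added groups or their identity separates compound 4 from compound 2 and compound 3, as the set holds no compound with a single fluorine or a single methyl on this ring. They also leave open how a methoxy group, an amine or a nitrile would read at the place taken by trifluoromethyl, and whether the ring could take a second group alongside it.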